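This account rests on a few compounds, and the source may have more. Where it says the series, first, only, none or still open, it means among the compounds named here.

Compounds measured in an assay on isolated protein for inhibition of Indoleamine 2,3-dioxygenase 1 (Homo sapiens); on this read-out lower numbers stand for stronger inhibition and higher numbers for weaker inhibition:

Compound 1, `OCCCc1cn(CCNc2nonc2/C(=N/O)Nc2ccc(F)c(Br)c2)nn1`: 98 nM
Compound 2, `O/N=C(\Nc1ccc(F)c(Br)c1)c1nonc1NCCn1cc(C2(O)CCCCC2)nn1`: 62 nM
Compound 3, `CC(OCCO)c1cn(CCNc2nonc2/C(=N/O)Nc2ccc(F)c(Br)c2)nn1`: 134 nM

Within this small set, compound 3 gives the highest number; its neighbour is compound 1, and the step of a 1.4-fold higher number from compound 1 to compound 3 (0.14 log units; within the scatter) stays within the scatter, while the step of a 2.2-fold higher number from compound 2 to compound 3 (0.33 log units; beyond the scatter) is a modest one beyond it. The step of a 1.6-fold lower number from compound 1 to compound 2 (0.20 log units; within the scatter) also lies within the scatter, so the three compounds are spread over a narrow band.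

The unmeasured compound 4, `CC(C)(OCCO)c1cn(CCNc2nonc2/C(=N/O)Nc2ccc(F)c(Br)c2)nn1`, differs from compound 3 by one change: methyl in place of hydrogen on a saturated chain carbon bound to an aromatic carbon, an oxygen on a saturated carbon and a saturated chain carbon. For the measured compounds named here, none of the measured steps adds a single methyl in this way; all three exchange the whole substituent on the aromatic carbon, and those exchanges moved this assay by small amounts at most. Nothing among them points to a large effect for this change, and no direction can be drawn from them. The expectation is therefore that compound 4 gives a number close to compound 3, with a step of a 1.1-fold lower number from compound 3 to compound 4 (0.05 log units; within the scatter) that is not expected to go beyond the scatter. Compound 4 is estimated at 120 nM, with a range from 60 nM to 250 nM.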

Compound 4, half-maximal inhibitory concentration: 176 nM
Compound 4: middle estimate off by 1.5-fold (0.17 log units), on the low side, within the range that was stated.
By their numbers in this assay, from the lowest: compounds 2, 1, 3 and 4 (each within the scatter of the next, the first and the last beyond it).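

In this assay, for the compounds shown here, the added methyl on the saturated chain carbon gives a 1.3-fold higher number from compound 3 to compound 4 (0.12 log units; within the scatter) and so leaves the number within the scatter, the first reading of a single-methyl change at this position, where the earlier steps had only exchanged whole substituents. The exchange of 3-hydroxypropyl for 1-(2-hydroxyethoxy)-1-methylethyl also stays within the scatter, with a 1.8-fold higher number from compound 1 to compound 4 (0.25 log units; within the scatter), whereas the exchange of 1-hydroxycyclohexyl for the same group gives a 2.8-fold higher number from compound 2 to compound 4 (0.45 log units; beyond the scatter), a modest step beyond it and the widest gap among the four compounds. Nothing shown gives any explanation for these numbers.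

With one methyl step on one substituent, the compounds shown leave open whether the same addition would behave alike with 3-hydroxypropyl or another chain on the aromatic carbon. They also leave open how this assay would respond to an amine or a carboxylic acid in place of the hydroxyl of the 2-hydroxyethoxy part, or to a longer chain carrying that hydroxyl.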